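Sulfonamide nitrogen substituent in two sugar-linked triazole series

The compounds below may be only part of what the source reports. "The series", "measured", "known", "first", "only" and "open" are said of these compounds alone.

Measured compounds:
compound 1 `COC(=O)CN(Cc1cn([C@@H]2O[C@H](COC(C)=O)[C@@H](OC(C)=O)[C@H]2OC(C)=O)nn1)S(C)(=O)=O` — 125000 nM
compound 2 `COC(=O)C(C)(C)N(Cc1cn([C@@H]2O[C@H](COC(C)=O)[C@@H](OC(C)=O)[C@H]2OC(C)=O)nn1)S(C)(=O)=O` — 50000 nM
compound 3 `COC(=O)CN(Cc1cn([C@@H]2O[C@H](COC(C)=O)[C@@H](OC(C)=O)[C@H](OC(C)=O)[C@H]2OC(C)=O)nn1)S(C)(=O)=O` — a limit only

In a functional assay on RCC4 cells (Homo sapiens) for antiproliferative activity, read by XTT assay, with a stated time of 48 h (a lower number here means a stronger inhibitor, a higher number a weaker inhibitor), compound 1 gives 125000 nM and compound 2 gives 50000 nM. The change between them is 1-(methoxycarbonyl)-1-methylethyl in place of (methoxycarbonyl)methyl on a sulfonamide nitrogen and it produced a 2.5-fold lower number from compound 1 to compound 2 (0.40 log units; beyond the scatter).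

Compound 3 `COC(=O)CN(Cc1cn([C@@H]2O[C@H](COC(C)=O)[C@@H](OC(C)=O)[C@H](OC(C)=O)[C@H]2OC(C)=O)nn1)S(C)(=O)=O` carries a different core; how the two cores differ is not broken down here. In this assay compound 3 gives > 250000 nM, which is a limit of the assay and not a number, a point at which (the limit of > 250000 nM in this assay, at which 1 of the 3 values shown sits).

Compound 4 `COC(=O)C(C)(C)N(Cc1cn([C@@H]2O[C@H](COC(C)=O)[C@@H](OC(C)=O)[C@H](OC(C)=O)[C@H]2OC(C)=O)nn1)S(C)(=O)=O` is not yet measured. It differs from compound 3 by 1-(methoxycarbonyl)-1-methylethyl in place of (methoxycarbonyl)methyl on a sulfonamide nitrogen, the same change that separates compound 1 from compound 2. If the change acts as it did there, the step from compound 3 to compound 4 is expected to be an at least 1.2-fold lower number from compound 3 to compound 4 (0.09 log units; that floor lies within the scatter), resting on a 2.5-fold lower number from compound 1 to compound 2 (0.40 log units; beyond the scatter) and on the limit of compound 3. Compound 4 is expected to give about 200000 nM, within 80000 nM to 500000 nM, with a fair chance that only a limit is reported.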

Compound 4, half-maximal inhibitory concentration: 240000 nM
Compound 4: the middle estimate sits 1.2-fold (0.08 log units) below what was measured; measured number inside the range.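

In this assay compound 3 gives > 250000 nM which is a limit of the assay and not a number. On that core, the change to 1-(methoxycarbonyl)-1-methylethyl in place of (methoxycarbonyl)methyl can therefore be read only as an at least 1.0-fold lower number from compound 3 to compound 4 (0.01 log units; that floor lies within the scatter) and this floor neither shows that the change carries over from the core of compound 1 at the same size nor shows that it fails to carry over. Set side by side, the two readings are these: the same change on two cores in this assay, a 2.5-fold lower number (0.40 log units; beyond the scatter) from compound 1 to compound 2 and an at least 1.0-fold lower number (0.01 log units; that floor lies within the scatter) from compound 3 to compound 4; the limit leaves it open whether they differ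

The compounds shown leave open whether a carboxylic acid in place of the methyl ester would follow the same course on both cores. They also leave open how a longer chain on the sulfonamide nitrogen, or free hydroxyl groups in place of the acetates on the sugar, would read in this assay on either core.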